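Ester for amide on the side chain of compound 2

The source may hold more compounds than are shown below. What is called first, only, known or untested is meant among the compounds shown, and "the series" means these compounds.

Of the compounds shown here, two have been measured in a functional assay on the whole organism (Tail, strain ICR) with Mus musculus as the target, in the tail flick test, with a stated time of 60 min, at a dose of 25 umol/kg by the oral route; on this read-out higher numbers stand for a stronger effect at the one dose given and lower numbers for a weaker effect. Compound 1 `O=C(CN(c1ncnc2c1ncn2C1CCCCO1)C1CC1)N[C@@H](CCC(=O)OCc1ccccc1)C(=O)OCc1ccccc1` gives 34.7%, and compound 2 `NC(=O)C[C@H](NC(=O)CN(c1ncnc2c1ncn2C1CCCCO1)C1CC1)C(=O)OCc1ccccc1` gives 30.5%. Within the data shown here, compound 2 stands alongside compound 1, the two values within the scatter of each other, since the only step between them, a number 4.2 percentage points lower from compound 1 to compound 2 (within the scatter), is small.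

Compound 3 `O=C(CN(c1ncnc2c1ncn2C1CCCCO1)C1CC1)N[C@@H](CC(=O)OCc1ccccc1)C(=O)OCc1ccccc1` differs from compound 2 by benzyloxy in place of amino on a carbonyl carbon. Among the measured compounds shown here, the one measured step that bears on this, from compound 1 to compound 2, also exchanged a carbamoyl-type group for a (benzyloxycarbonyl)-type group on the same side chain and stayed within the scatter. No step beyond the scatter is therefore expected in this assay on going from compound 2 to compound 3; the expected step is a number 2.5 percentage points higher from compound 2 to compound 3 (within the scatter). Compound 3 is accordingly estimated at 33%, within a range of 18% to 48%.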

Compound 3, a percentage reported as activity, at one dose (the size of the read-out at that dose, not a potency): 38.2%
Estimate against measurement, compound 3: 5.2 percentage points below, and the stated range covers the measured number.
By their numbers in this assay, from the lowest: compounds 2, 1 and 3 (each within the scatter of the next).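

The earlier step from compound 1 to compound 2 changed the end group and the chain together, and compound 3 now lets each change be read alone. With the chain held, benzyloxy in place of amino on the carbonyl carbon gives a number 7.7 percentage points higher from compound 2 to compound 3 (within the scatter) in this assay, so this read-out does not separate the benzyl ester from the primary amide at this position. With the end group held, benzyloxycarbonyl in place of (benzyloxycarbonyl)methyl gives a number 3.5 percentage points higher from compound 1 to compound 3 (within the scatter), so that change in the side chain is not resolved either, and no available evidence bears on these results.

Going by these compounds, whether a carboxylic acid or an amine at this chain end, or a longer chain bearing benzyloxycarbonyl, would move the read-out beyond the scatter stays open. A single dose also leaves open whether the three compounds would show a stronger or weaker effect relative to one another at other doses.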